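Bromo for phenyl on the pendant ring: cytotoxicity outlook

A few compounds are considered here, and "the series" means these few. Any claim that something is new, unique, unknown or untested is made for them only; others in the source may bear on it.

Working notes on the series. The three measured compounds share the core of compound 1 `CCOC(=O)c1c(-c2cccc(-c3ccccc3)c2)[nH]c2cc(OC)ccc2c1=O` and differ only in the group carried on the pendant aromatic ring. In an ADME assay on Raji cells (Homo sapiens) for cytotoxicity, read by luminescence, with a stated time of 72 h (on this read-out higher numbers stand for an effect only at larger amounts of compound and lower numbers for an effect already at smaller amounts), compound 1 is reported only as a limit of the assay, > 21500 nM. Compound 2 `CCOC(=O)c1c(-c2cccc(OC)c2)[nH]c2cc(OC)ccc2c1=O` carries methoxy in place of phenyl on an aromatic carbon; in this assay compound 2 likewise stops at a limit, > 21500 nM. Compound 3 `CCOC(=O)c1c(-c2cccc(OCc3ccccc3)c2)[nH]c2cc(OC)ccc2c1=O` carries benzyloxy in place of phenyl on an aromatic carbon; in this assay compound 3 also gives only a limit, > 21500 nM. The steps a step that the two limits leave unreadable from compound 1 to compound 2, a step that the two limits leave unreadable from compound 1 to compound 3 and a step that the two limits leave unreadable from compound 2 to compound 3 cannot be sized because of the limit of > 21500 nM in this assay, at which 3 of the 3 values shown sit.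

Compound 4 `CCOC(=O)c1c(-c2cccc(Br)c2)[nH]c2cc(OC)ccc2c1=O` is the next member, and its change from compound 1 is bromo in place of phenyl on an aromatic carbon. Going by the values given here, none of the measured steps bears a readable size on this change, so no direction beyond the scatter can be argued for this assay; what the three measured compounds do show is that every variation of this group so far has been read only as a limit. Compound 4 is therefore expected to give about 25000 nM in this assay, with an expected range from 10000 nM to 60000 nM. That estimate means an expected step that the limit leaves unreadable from compound 1 to compound 4, most likely reported as a further limit rather than a number.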

Compound 4, half-maximal effective concentration: > 21500 nM
Compound 4: no number, only a limit (the forecaster's own chance of this, stated with the estimate: 80%); the middle value lies beyond the limit too.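

In this assay compound 4 also gives only a limit, > 21500 nM. Its steps from compound 1, compound 2 and compound 3 cannot be read, because the values stop at the same limit: the limit of > 21500 nM in this assay, at which 4 of the 4 values shown sit.

The compounds shown leave open how compound 1, compound 2, compound 3 and compound 4 compare in cytotoxicity, and whether any group on the pendant ring gives a readable number.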